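Sulfonamide series: para-chloro replacing para-ethyl in cytotoxicity

This account rests on a few compounds, and the source may have more. Where it says the series, first, only, none or still open, it means among the compounds named here.

Working notes on the shared core of compound 1 `O=S(=O)(Nc1ccc(-c2nc3ccccc3o2)cc1)c1cccc(F)c1`, compound 2 `O=S(=O)(Nc1ccc(-c2nc3ccccc3o2)cc1)c1ccc(Cl)c(C(F)(F)F)c1`, compound 3 `CCc1ccc(S(=O)(=O)Nc2ccc(-c3nc4ccccc4o3)cc2)cc1` and the unmeasured compound 4 `O=S(=O)(Nc1ccc(-c2nc3ccccc3o2)cc1)c1ccc(Cl)cc1`. In an ADME assay on HEK293 cells (Homo sapiens) for cytotoxicity, read by resazurin assay, with a stated time of 48 h (on this read-out higher numbers stand for lower toxicity in this test and lower numbers for higher toxicity in this test), compound 1 reaches only the assay limit, > 100000 nM. In this assay compound 2 gives 69000 nM and compound 3 gives 82000 nM, the two numbers within the scatter of each other. Within the data shown here, the one measured step, an at least 1.2-fold lower number from compound 1 to compound 3 (0.08 log units; that floor lies within the scatter), rests on a limit, (the limit of > 100000 nM in this assay, at which 1 of the 3 values shown sits), and says little. Compound 4 differs from compound 3 by chloro in place of ethyl on an aromatic carbon. Among the measured compounds shown here, no measured step covers this change alone; compound 2, which carries chloro with a further trifluoromethyl, sits close to compound 3. Compound 4 is therefore expected near compound 3, a step of a 1.1-fold lower number from compound 3 to compound 4 (0.04 log units; within the scatter), at an estimated 75000 nM with a range of 35000 nM to 160000 nM.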

Compound 4, half-maximal cytotoxic concentration: > 100000 nM
Compound 4: no number, only a limit (the forecaster's own chance of this, stated with the estimate: 25%); middle value at least 1.3-fold (0.12 log units) from the limit.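

Chloro in place of ethyl on this aromatic carbon, para to a large group, gives no sign of a lower number: an at least 1.2-fold higher number from compound 3 to compound 4 (0.08 log units; that floor lies within the scatter). Hydrogen in place of trifluoromethyl on the chloro-bearing ring reads the same way, an at least 1.4-fold higher number from compound 2 to compound 4 (0.16 log units; that floor lies within the scatter). Compound 4 gives only a limit, as does compound 1, the step between them cannot be read, and both readable floors lie within the scatter: the limit of > 100000 nM in this assay, at which 2 of the 4 values shown sit.

Open, as far as these compounds go, is whether an amine, a carboxylic acid or a longer chain on this aromatic carbon would move the number beyond the scatter in this assay. Also open, from the compounds shown here alone, is how far past the limit compound 1 and compound 4 lie.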